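Replacing a dimethoxyphenyl with a trifluoromethoxyphenyl sulfonyl group

The compounds below may be only part of what the source reports. "The series", "measured", "known", "first", "only" and "open" are said of these compounds alone.

Measured compounds:
compound 1 `CN(c1ccc2[nH]c(-c3n[nH]c4ccccc34)cc2n1)S(=O)(=O)c1ccccc1`: 2400 nM
compound 2 `COc1ccc(OC)c(S(=O)(=O)N(C)c2ccc3[nH]c(-c4n[nH]c5ccccc45)cc3n2)c1`: 4380 nM
compound 3 `COc1ccc(S(=O)(=O)N(C)c2ccc3[nH]c(-c4n[nH]c5ccccc45)cc3n2)c(OC)c1`: 10200 nM

These three compounds share one core and differ only in the aryl group on the sulfonyl sulfur. In a functional assay on KB cells (Homo sapiens) for antiproliferative activity, read by MTT assay, with a stated time of 72 h (a lower number here means a stronger inhibitor, a higher number a weaker inhibitor), compound 3 gives 10200 nM, the highest number of the three; the nearest is compound 2, and the step of a 2.3-fold higher number from compound 2 to compound 3 (0.37 log units; beyond the scatter) lies beyond the scatter, while the step of a 4.3-fold higher number from compound 1 to compound 3 (0.63 log units; beyond the scatter) is larger still. The step of a 1.8-fold higher number from compound 1 to compound 2 (0.26 log units; within the scatter) stays within the scatter.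

Compound 4 `CN(c1ccc2[nH]c(-c3n[nH]c4ccccc34)cc2n1)S(=O)(=O)c1ccc(OC(F)(F)F)cc1` is the next member. The change is 4-(trifluoromethoxy)phenyl in place of 2,4-dimethoxyphenyl on a sulfonyl sulfur. Among the compounds with values here, the steps that bear on it are a 4.3-fold higher number from compound 1 to compound 3 (0.63 log units; beyond the scatter) and a 2.3-fold higher number from compound 2 to compound 3 (0.37 log units; beyond the scatter), both showing that the 2,4-dimethoxyphenyl gives a higher number than the other two aryl groups in this assay. Within the data shown here, no measured compound carries a 4-(trifluoromethoxy)phenyl, so the new group itself is untested. Moving away from the 2,4-dimethoxyphenyl is expected to bring compound 4 back toward the range of compound 1 and compound 2, an estimated step of a 2.9-fold lower number from compound 3 to compound 4 (0.46 log units; beyond the scatter). Compound 4 is therefore estimated at 3500 nM, with a range from 1200 nM to 10000 nM in this assay.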

Compound 4, half-maximal inhibitory concentration: 1330 nM
The estimate for compound 4 lay 2.6-fold (0.42 log units) above the measured number, and the stated range covers the measured number.
By their numbers in this assay, from the lowest: compounds 4, 1 and 2 (each within the scatter of the next, the first and the last beyond it); then compound 3.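

In this assay the 4-(trifluoromethoxy)phenyl on the sulfonyl sulfur gives a lower number than the 2,4-dimethoxyphenyl (a 7.7-fold lower number from compound 3 to compound 4 (0.88 log units; beyond the scatter)) and the 2,5-dimethoxyphenyl (a 3.3-fold lower number from compound 2 to compound 4 (0.52 log units; beyond the scatter)). A substituent on this aryl ring therefore need not raise the number, which the earlier substituted compounds, both dimethoxyphenyl, could not show. The remaining step (a 1.8-fold lower number from compound 1 to compound 4 (0.26 log units; within the scatter)) stays within the scatter, so trifluoromethoxy and hydrogen on this aromatic carbon cannot be told apart here, and no measurement is given that accounts for any of these steps.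

As far as these compounds go, it remains open whether a single methoxy, a trifluoromethyl or a chlorine on the phenyl ring would match compound 4 or compound 3. From the compounds shown here alone, whether an amine or a carboxylic acid would be accepted on that ring is also open.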